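From methoxy to (3-phenylpropyl)amino in this series

A few compounds are considered here, and "the series" means these few. Any claim that something is new, unique, unknown or untested is made for them only; others in the source may bear on it.

Going by the values given here, in a functional assay for inhibition, with Rattus norvegicus as the target, at pH 7.35 (on this read-out lower numbers stand for stronger inhibition and higher numbers for weaker inhibition), compound 1 (`CCC(NC(=O)C(CC(C)C)NC(=O)OCc1ccccc1)C(=O)C(=O)OC`) gives 280000 nM as the only true number so far, with no measured neighbour to rank it against. Compound 2 (`CCOC(=O)C(=O)C(CC)NC(=O)C(CC(C)C)NC(=O)C(c1ccccc1)c1ccccc1`) reads > 100000 nM and this is a limit of the assay, not a number. Compound 3 (`CCC(NC(=O)C(CC(C)C)NC(=O)OCc1ccccc1)C(=O)C(=O)NCCCc1ccccc1`) has yet to be measured. It carries (3-phenylpropyl)amino in place of methoxy on a carbonyl carbon, counted in full as (3-phenylpropyl)amino in place of methoxy on a carbonyl carbon in the comparison with compound 1. Among the compounds with values here, no measured step covers this change, so the expectation rests on the structural change alone and remains loose. Expected is a 5.6-fold lower number from compound 1 to compound 3 (0.75 log units; beyond the scatter) in the direction of stronger inhibition in this assay and somewhat beyond the usual scatter. For compound 3 the estimated value is 50000 nM with an expected range of 8000 nM to 250000 nM in this read-out.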

Compound 3, half-maximal inhibitory concentration: 100000 nM
Compound 3: middle estimate off by 2.0-fold (0.30 log units), on the low side; low and high end bracket the measured number.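

Going by these compounds alone, the first readable step falls on this carbonyl carbon: in this assay, (3-phenylpropyl)amino in place of methoxy gives a 2.8-fold lower number from compound 1 to compound 3 (0.45 log units; beyond the scatter). The change brings in a six-membered aromatic ring and a hydrogen-bond donor together, and this single step cannot separate the two. The number remains high in absolute terms, with compound 3 at 100000 nM.

On these data alone, whether the shift follows from the amide nitrogen or the phenyl ring stays open, and a plain ethylamino group, a shorter benzylamino chain or a carboxylic acid on the same carbonyl carbon would bear on that. Within the data shown here, compound 2 differs from compound 1 in more than one place and reads as a limit, not a number, so it adds no step: the limit of > 100000 nM in this assay, at which 1 of the 3 values shown sits.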